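This account rests on a few compounds, and the source may have more. Where it says the series, first, only, none or still open, it means among the compounds named here.

Measured in a functional assay on NCI-H1975 cells (Homo sapiens) for inhibition, read by MTT assay, with a stated time of 72 h; a lower number here means a stronger inhibitor, a higher number a weaker inhibitor:
compound 1 `O=C(CSc1nc(Nc2ccccc2)c2ccccc2n1)Nc1ccc([N+](=O)[O-])cc1` gives 13000 nM
compound 2 `O=C(CSc1nc(Nc2ccccc2)c2ccccc2n1)Nc1ccc(Cl)c(Cl)c1` gives 10400 nM
compound 3 `C=CC(=O)Nc1cccc(NC(=O)CSc2nc(Nc3cccc([N+](=O)[O-])c3)c3ccccc3n2)c1` gives 22600 nM

Compound 3 has the highest number of the three, but its gap to compound 1 lies within the scatter; only compound 2 sits beyond it, with a lower number. Compound 4 `C=CC(=O)Nc1cccc(NC(=O)CSc2nc(Nc3ccc(F)c(Cl)c3)c3ccccc3n2)c1` differs from compound 3 by 3-chloro-4-fluorophenyl in place of 3-nitrophenyl on a nitrogen on an aromatic ring. Among the compounds with values here, one measured step bears on this: the swap of a nitro-bearing phenyl for a halogen-bearing phenyl on an amide-type nitrogen, a 1.3-fold lower number from compound 1 to compound 2 (0.10 log units; within the scatter). That step stayed within the scatter, and it sits at a different place in the molecule, so the expectation is no change beyond the scatter in this assay, a 1.1-fold lower number from compound 3 to compound 4 (0.05 log units; within the scatter). Compound 4 is therefore estimated at 20000 nM, within 9000 nM to 45000 nM.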

Compound 4, half-maximal inhibitory concentration: > 50000 nM
Compound 4 gave a limit, no number; the forecaster's own chance of this, stated with the estimate: 10%; middle value at least 2.5-fold (0.39 log units) away from the limit.
By their numbers in this assay, from the lowest: compounds 2, 1 and 3 (each within the scatter of the next, the first and the last beyond it). At a limit, above all of these: compound 4.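

In this assay compound 4 gives > 50000 nM, which is a limit of the assay and not a number. Even so, 3-chloro-4-fluorophenyl in place of 3-nitrophenyl on this nitrogen gives an at least 2.2-fold higher number from compound 3 to compound 4 (0.34 log units; beyond the scatter), so this place responds to the change, while the swap on the amide-type nitrogen gave a 1.3-fold lower number from compound 1 to compound 2 (0.10 log units; within the scatter), within the scatter.

As far as these compounds go, the full size of the new step cannot be read from a limit: the limit of > 50000 nM in this assay, at which 1 of the 4 values shown sits. It also remains open whether 3-chlorophenyl, 4-fluorophenyl or 3-aminophenyl on this nitrogen would behave like compound 3 or like compound 4.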